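The source may hold more compounds than are shown below. What is called first, only, known or untested is meant among the compounds shown, and "the series" means these compounds.

Measured compounds:
compound 1, `COc1ccccc1C(=O)NCc1ccc(CNS(=O)(=O)c2ccccc2C)cc1`: 1000 nM
compound 2, `COc1ccccc1C(=O)NCc1ccc(CNS(=O)(=O)c2ccc(Cl)cc2)cc1`: 1000 nM

In an assay on MDA-MB-231 cells for displacement of a labelled ligand from C-X-C chemokine receptor type 4 (Homo sapiens), read by fluorescence and microscopy, with stated times of 10 min and 30 min (on this read-out lower numbers stand for an effect already at smaller amounts and higher numbers for an effect only at larger amounts of compound), compound 1 gives 1000 nM, and compound 2 gives 1000 nM. Among the measured compounds shown here, the one measured step, no change at the digits printed from compound 1 to compound 2 (within the scatter), put a 4-chlorophenyl in place of a 2-methylphenyl on the sulfonyl sulfur and stayed within the scatter, so compound 2 stands level with compound 1 on this read-out.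

Compound 3, `COc1ccccc1C(=O)NCc1ccc(CNS(=O)(=O)c2ccc(F)cc2)cc1`, has not yet been measured. It differs from compound 2 only by fluoro in place of chloro on an aromatic carbon. For the measured compounds named here, the only step with any bearing is no change at the digits printed from compound 1 to compound 2 (within the scatter), which altered the aryl group on the same sulfonyl sulfur without moving the number. Going by the values given here, no measured pair tests a halogen swap directly, so the expected step is no change at the digits printed from compound 2 to compound 3 (within the scatter), meaning none beyond the scatter. The estimate for compound 3 in this assay is 1000 nM, within 400 nM to 2500 nM.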

Compound 3, effective concentration (reported as EC, without a stated level of effect): 100 nM
Compound 3: middle estimate off by 10-fold (1.00 log units), on the high side, outside the stated range (below it).
By their numbers in this assay, from the lowest: compound 3; then compounds 1 and 2 (each within the scatter of the next).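

The earlier step showed that the aryl group on the sulfonyl sulfur could change with no effect on the number, but this position is not indifferent to which halogen it carries. In this assay, fluoro in place of chloro gives a 10-fold lower number from compound 2 to compound 3 (1.00 log units; beyond the scatter), even though only one heavy atom is exchanged for another at the same aromatic carbon. The 4-fluorophenyl group also separates from the 2-methylphenyl group, with a 10-fold lower number from compound 1 to compound 3 (1.00 log units; beyond the scatter), and no measurement here explains why the fluoro compound differs from the other two.

Whether the gain is specific to fluoro remains open, as the compounds shown include no 4-bromophenyl, 4-cyanophenyl or 4-aminophenyl group for comparison. They also do not show whether fluoro would have the same effect at another place on this ring.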